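The source may hold more compounds than are shown below. What is called first, only, known or untested is meant among the compounds shown, and "the series" means these compounds.

Measured compounds:
Compound 1 `CO[C@@H]1[C@H](OC(=O)NC(=O)CCl)CO[C@]2(COC(C)(C)O2)[C@@]1(OC(=O)CCl)C1(C)CO1` gives 38000 nM in a functional assay on A-431 cells (Homo sapiens) for antiproliferative activity; on this read-out higher numbers stand for weaker inhibition and lower numbers for stronger inhibition.
Compound 3 `CO[C@@H]1[C@H](OC(=O)NC(=O)CCl)CO[C@]2(COC(=O)O2)[C@]1(CCCCCc1ccccc1)OC(=O)NC(=O)CCl` gives 2000 nM in this assay.
Compound 2 `C=C(C)[C@@]1(O)[C@H](OC)[C@H](OC)CO[C@]12CO2` reaches only the limit of this assay, > 500000 nM, so no number is known for it.

Compound 1 stands at the highest of the two numbers, compound 3 sitting a long way beneath it, a gap beyond the usual scatter. Compound 4 `CO[C@@H]1[C@H](OC(=O)NC(=O)CCl)CO[C@]2(COC(C)(C)O2)[C@@]1(OC)C1(C)CO1` differs from compound 1 in one place: methyl in place of (chloromethyl)carbonyl on an oxygen on a saturated carbon. Among the compounds with values here, no measured pair here differs by this same change, so no measured step can guide the expectation. The step from compound 1 to compound 4 is expected to be small, a 1.6-fold higher number from compound 1 to compound 4 (0.20 log units; within the scatter), with a slightly weaker compound 4 somewhat more likely than a stronger one. Compound 4 is therefore estimated at 60000 nM, with a plausible range from 12000 nM to 400000 nM.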

Compound 4, half-maximal inhibitory concentration: 39000 nM
Compound 4: middle estimate off by 1.5-fold (0.19 log units), on the high side; the measured number falls inside the stated range.
By their numbers in this assay, from the lowest: compound 3; then compounds 1 and 4 (each within the scatter of the next). At a limit, above all of these: compound 2.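

In this assay, the step of a 1.0-fold higher number from compound 1 to compound 4 (0.01 log units; within the scatter) shows that on the core of compound 1, (chloromethyl)carbonyl on this oxygen can give way to the much smaller methyl without a shift beyond the scatter. Within the data shown here, the earlier compounds offered no pair that isolated this position, so this is the first direct reading of it. Nothing measured here explains why the two values match.

Going by these compounds, what a longer chain, an amine or a carboxylic acid on this oxygen would do remains open.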